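Adding one fluoro to compound 2

The compounds below may be only part of what the source reports. "The series", "measured", "known", "first", "only" and "open" are said of these compounds alone.

Measured so far in a functional assay on V79 cells (Cricetulus griseus) for cytotoxicity, read by colony formation; a higher number here means a weaker inhibitor, a lower number a stronger inhibitor
- compound 1 `CCNCC1CCN(c2c(F)cc3c(=O)c(C(=O)O)cn(C4CC4)c3c2F)C1` gives 11 ug/mL; 11 ug/mL; 11 ug/mL; 11 ug/mL (4 entries) across four entries
- compound 2 `NC1CCN(c2cc3c(cc2F)c(=O)c(C(=O)O)cn3C2CC2)CC1` gives 230 ug/mL with one further entry lacking a single number

Compound 2 holds the higher number of the two and reads as the weaker inhibitor. Compound 3 `NC1CCN(c2c(F)cc3c(=O)c(C(=O)O)cn(C4CC4)c3c2F)CC1` differs from compound 2 by fluoro in place of hydrogen on an aromatic carbon and keeps the 4-aminopiperidin-1-yl group. Going by the values given here, no measured step isolates this change. Compound 1 at 11 ug/mL; 11 ug/mL; 11 ug/mL; 11 ug/mL (4 entries) carries this fluoro with a different amine, so the number is expected to fall. The expected change is a 3.3-fold lower number from compound 2 to compound 3 (0.52 log units; beyond the scatter) toward a stronger inhibitor, beyond the scatter. Estimated for compound 3 is 70 ug/mL within an expected range from 25 ug/mL to 200 ug/mL.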

Compound 3, half-maximal inhibitory concentration: 23 ug/mL
Compound 3: the middle estimate sits 3.0-fold (0.48 log units) above what was measured; measured number outside the range, below it.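

In this assay, going by these compounds alone, fluoro in place of hydrogen ortho to the 4-aminopiperidin-1-yl group gives a 10-fold lower number from compound 2 to compound 3 (1.00 log units; beyond the scatter) and is the first single-place step. With the amine unchanged, this step shows that substitution at this aromatic carbon alone moves the number beyond the scatter. Nothing available accounts for the size of the step. Open, on these data alone, is whether chloro or methoxy at this position would move the number in the same direction. Also open, as far as these compounds go, is whether the fluoro step carries over to an ethylaminomethyl-substituted amine on the shared core.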